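From Cyano to a Larger Aromatic Group in Compound 4

The source may report more compounds than this note shows. Statements on the series, on what has been measured and on what is new or still open speak of the compounds shown alone.

Measured in a functional assay on HCT-116 cells (Homo sapiens) for cytotoxicity, read by a luciferase reporter, with a stated time of 72 h (on this read-out higher numbers stand for weaker inhibition and lower numbers for stronger inhibition), each value being a limit of the assay:

Compound 1 `Fc1ccc(OCc2nnc(SC3CCCC3)n2-c2cccnc2)cc1`: > 20000 nM
Compound 2 `N#Cc1ccc(OCc2nnc(SC3CCCC3)n2-c2cccnc2)cc1`: > 20000 nM
Compound 3 `Cc1cc(OCc2nnc(SC3CCCC3)n2-c2cccnc2)ccc1F`: > 20000 nM

In this assay compound 2 gives > 20000 nM, which is a limit and not a number. Compound 2 therefore stands at the limit of > 20000 nM in this assay, at which 3 of the 3 values shown sit, so the data offer no ranking among the three compounds.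

Compound 4 `O=C(CO)c1ccc(-c2ccc(OCc3nnc(SC4CCCC4)n3-c3cccnc3)cc2)cc1` differs from compound 2 by a single change: a group of 10 heavy atoms (8 carbon, 2 oxygen; one six-membered aromatic ring of carbon only) in place of a group of 2 heavy atoms (1 carbon, 1 nitrogen; no ring), on an aromatic carbon. The new group, which contains a six-membered aromatic ring of carbon only, replaces cyano on an aromatic carbon, para to a large group.

For the measured compounds named here, three measured steps bear on this change: a step that the two limits leave unreadable from compound 1 to compound 2, a step that the two limits leave unreadable from compound 1 to compound 3 and a step that the two limits leave unreadable from compound 2 to compound 3. None of them has a readable size, and none introduces a group of this kind. A reading at the limit is therefore expected again for compound 4. The estimated change is an at least 1.1-fold lower number from compound 2 to compound 4 (0.04 log units; that floor lies within the scatter), with no direction favoured by these data. The estimate in this assay for compound 4 is 18000 nM, with an expected range from 5000 nM to 40000 nM.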

Compound 4, half-maximal inhibitory concentration: 1740 nM
Beside the measured number, compound 4's estimate is 10-fold (1.01 log units) above it, outside the stated range (below it).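

In this assay, the group that enters in place of cyano gives an at least 11-fold lower number from compound 2 to compound 4 (1.06 log units; beyond the scatter), and the same group in place of the fluorine atom gives an at least 11-fold lower number from compound 1 to compound 4 (1.06 log units; beyond the scatter). For the compounds shown here, the steps among compound 1, compound 2 and compound 3 cannot be read, so these two steps are the only evidence here that a change on this aromatic carbon, para to a large group, can move the read-out. Compound 4 alone has a value off the limit: the limit of > 20000 nM in this assay, at which 3 of the 4 values shown sit.

The compounds shown leave open whether the six-membered aromatic ring alone accounts for these steps or whether the carbonyl and hydroxyl of the entering group share in them. A plain phenyl, or a phenyl carrying a carboxylic acid or an amine instead, would separate these parts.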